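Halogen exchange on the phenoxy group of compound 2

The compounds below may be only part of what the source reports. "The series", "measured", "known", "first", "only" and "open" are said of these compounds alone.

Compound 2 `CCc1nn(C)c(CO/N=C/c2c(C)nn(C)c2Oc2ccccc2F)c1Cl` is the starting point of this step. In a functional assay on SMMC-7721 cells (Homo sapiens) for inhibition, read by MTT assay, with a stated time of 72 h, tested at 25 uM (a lower number here means less inhibition, a higher number more inhibition at the concentration tested (going by the name of the read-out)), compound 2 reaches only a limit of the assay, < 80%, so no number is known for it. Compound 1 `Cc1nn(C)c(Oc2ccc(F)cc2)c1/C=N\OCc1c(Cl)c(-c2ccc(F)cc2)nn1C` is a related member of the series; in this assay compound 1 gives 80%. Compound 3 `Cc1nn(C)c(Oc2ccc(Cl)cc2)c1/C=N\OCc1c(Cl)c(-c2ccc(F)cc2)nn1C` differs from compound 1 by chloro in place of fluoro on an aromatic carbon; in this assay compound 3 gives 80%. Within the data shown here, that comparison, no change at the digits printed from compound 1 to compound 3 (within the scatter), is the only measured step that exchanges one halogen for another, and it stayed within the scatter.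

Compound 4 `CCc1nn(C)c(CO/N=C/c2c(C)nn(C)c2Oc2ccc(Br)cc2)c1Cl` carries the change (4-bromophenyl in place of 2-fluorophenyl on an oxygen on an aromatic ring). The measured halogen exchange moved nothing beyond the scatter, and for compound 2 only the limit of < 80% in this assay, at which 1 of the 3 values shown sits, is available as a point of reference. The step expected from this exchange, a step that the limit leaves unreadable from compound 2 to compound 4, is estimated to be small, with the outcome most likely remaining a limit rather than a number. Compound 4 is expected to give 55% in this assay, within a range from 20% to 82%.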

Compound 4, a percentage reported as inhibition, at one concentration (the size of the read-out at that concentration, not a potency): < 80%
Compound 4: only a limit was reported; the forecaster's own chance of this, stated with the estimate: 65%; the middle value lies beyond the limit too.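

Compound 2 and compound 4 are both reported only as limits in this assay, so no step between them can be read: the limit of < 80% in this assay, at which 2 of the 4 values shown sit.

The compounds shown leave open whether 4-bromophenyl in place of 2-fluorophenyl on an oxygen on an aromatic ring changes inhibition at all in this assay.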